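This account rests on a few compounds, and the source may have more. Where it says the series, first, only, none or still open, it means among the compounds named here.

In a functional assay on HEL cells (Homo sapiens) for cytotoxicity (on this read-out lower numbers stand for higher toxicity in this test and higher numbers for lower toxicity in this test), compound 1 `CCCCC#Cc1cc2cn([C@@H]3O[C@H](CO)[C@@H](O)[C@H]3O)c(=O)nc2o1` gives > 144000 nM, which is a limit and not a number. Compound 2 `CCCCC#Cc1cc2cn(C)c(=O)nc2o1` gives > 217000 nM, also a limit. Compound 3 `CCCCCCC#Cc1cc2cn([C@@H]3O[C@H](CO)[C@@H](O)[C@H]3O)c(=O)nc2o1` gives > 133000 nM, again a limit. No exact value is therefore available in this small set.

Compound 4 `CCCCC#Cc1cc2cn([C@@H]3O[C@H](CO)[C@@H](O)[C@@H]3O)c(=O)nc2o1` is related to compound 1 by the two compounds have the same atoms and bonds and differ only in configuration as drawn: 1 of 4 stereo elements differ; a stereocentre at a saturated ring carbon is drawn R in compound 1 and S in compound 4. The two compounds have the same atoms and bonds and differ only in configuration as drawn, at a stereocentre at a saturated ring carbon.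

Among the compounds with values here, the one measured step, a step that the two limits leave unreadable from compound 1 to compound 3, concerns a change on the chain and not a change of configuration, so it offers no size to carry over. Within the data shown here, no measured step tests this kind of change. No shift beyond the scatter is expected in this assay, in either direction. The expected step is a number no higher from compound 1 to compound 4 (the limit leaves the size open). Compound 4 will most likely also be reported as a limit. For compound 4 the estimated value is 144000 nM, with an expected range from 60000 nM to 300000 nM.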

Compound 4, half-maximal cytotoxic concentration: > 144000 nM
Compound 4 was reported as a limit; the forecaster's own chance of this, stated with the estimate: 85%; the middle value lies on the limit itself.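

In this assay compound 4 gives > 144000 nM, which is a limit. Compound 1 gives > 144000 nM, also a limit. No step can be read between compound 1 and compound 4. The compounds shown leave open whether the configuration at this saturated ring carbon changes the cytotoxic concentration at all.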